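The source may hold more compounds than are shown below. What is called first, only, known or untested is meant among the compounds shown, and "the series" means these compounds.

Three compounds have been measured in a functional assay on HeLa cells (Homo sapiens) for inhibition, read by sulforhodamine B assay; a lower number here means a stronger inhibitor, a higher number a weaker inhibitor:

Compound 1 `O=C1C(N2CCCC2)=CC(=O)c2c1nc1n2[C@H]2OC[C@@H](O)[C@H]2OC1` gives > 16000 nM, a limit of the assay rather than a number.
Compound 2 `O=C1C=C(Nc2cccc(F)c2)C(=O)c2c1nc1n2[C@H]2OC[C@@H](O)[C@H]2OC1` gives 6440 nM.
Compound 3 `O=C1C(N2CCC2)=CC(=O)c2c1nc1n2[C@H]2OC[C@@H](O)[C@H]2OC1` gives > 16000 nM, again a limit of the assay.

For the measured compounds named here, compound 2 therefore stands alone as the only measured number; the two other compounds sit at the limit of > 16000 nM in this assay, at which 2 of the 3 values shown sit. Going by the values given here, the single step between measured compounds that differ in one place, a step that the two limits leave unreadable from compound 1 to compound 3, concerns the exchange of azetidin-1-yl for pyrrolidin-1-yl on a double-bonded ring carbon, and its size cannot be read from two limits. It touches a different part of the shared core and says nothing about the anilino side.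

Compound 4 `O=C1C=C(Nc2ccccc2)C(=O)c2c1nc1n2[C@H]2OC[C@@H](O)[C@H]2OC1` differs from compound 2 by hydrogen in place of fluoro on an aromatic carbon, that is, 3-fluorophenyl becomes phenyl and (3-fluorophenyl)amino becomes anilino. Among the compounds with values here, no measured step bears on this change, so no direction beyond the scatter can be argued from the data. The value of compound 4 in this assay is estimated at 7500 nM, with a range from 3000 nM to 16000 nM. For compound 4 the step this estimate implies is expected to be a 1.2-fold higher number from compound 2 to compound 4 (0.07 log units; within the scatter), within the usual scatter.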

Compound 4, half-maximal inhibitory concentration: 5620 nM
Beside the measured number, compound 4's estimate is 1.3-fold (0.13 log units) above it; the measured number falls inside the stated range.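

In this assay, for the compounds shown here, hydrogen in place of fluoro on the aromatic carbon gives a 1.1-fold lower number from compound 2 to compound 4 (0.06 log units; within the scatter) and so provides the first step that can be read, since the one earlier step joins two limits of the assay and has no readable size. Going by these compounds alone, it shows that, at this place on the six-membered aromatic ring of the anilino side, fluoro and hydrogen give values within the scatter of each other, something the earlier compounds could not show because compound 2 was the only one with a number. The finding covers this single exchange at this single place, and no measured property in the data bears on the result.

Going by these compounds, whether the same holds for chloro, methoxy, trifluoromethyl or a carboxylic acid at this place on the ring stays open, as does the outcome for any of these groups elsewhere on that ring. Also open, on these data alone, is what a methyl group on the anilino nitrogen, in place of its hydrogen, would do to the number.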